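The compounds below may be only part of what the source reports. "The series", "measured", "known", "first", "only" and "open" are said of these compounds alone.

Measured compounds in an ADME assay on KB cells (Homo sapiens) for cytotoxicity, read by MTT assay, with a stated time of 72 h; a higher number here means a weaker inhibitor, a lower number a stronger inhibitor:
- compound 1, `COc1ccc(C2=C(c3cc(OC)c(OC)c(OC)c3)C(=O)C(O[SiH2]C(C)(C)C)C2)cc1OC(C)C`, 7.5 ug/mL
- compound 2, `COc1ccc(C2=C(c3cc(OC)c(OC)c(OC)c3)C(=O)C(O[SiH2]C(C)(C)C)C2)cc1`, 7 ug/mL

Compound 2 gives the lower of the two numbers in this assay, but the step of a 1.1-fold lower number from compound 1 to compound 2 (0.03 log units; within the scatter) is within the scatter, so compound 2 and compound 1 are not separable on these data and neither is called the stronger.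

Compound 3, `COc1cc(C2=C(c3ccc(SC)cc3)CC(O[SiH2]C(C)(C)C)C2=O)cc(OC)c1OC`, is not yet measured. It differs from compound 2 as follows: methylsulfanyl in place of methoxy on an aromatic carbon.

Among the compounds with values here, only one measured step exists in the set, and it concerns a different change at a different place on the core, so no measured step bears directly on methylsulfanyl in place of methoxy on an aromatic carbon. Within the data shown here, the one step available, a 1.1-fold lower number from compound 1 to compound 2 (0.03 log units; within the scatter), showed a small aromatic substituent change leaving the number within the scatter.

Among the measured compounds shown here, with no relevant precedent, compound 3 is expected to stay near compound 2 in this assay, the expected step of no change at the digits printed from compound 2 to compound 3 (within the scatter) being no larger than the scatter. The estimate for compound 3 is 7 ug/mL, with a range of 3 ug/mL to 16 ug/mL.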

Compound 3, half-maximal inhibitory concentration: 10 ug/mL
Compound 3: the middle estimate sits 1.4-fold (0.15 log units) below what was measured, and the stated range covers the measured number.
By their numbers in this assay, from the lowest: compounds 2, 1 and 3 (each within the scatter of the next).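

Within the data shown here, replacing methoxy with methylsulfanyl on an aromatic carbon, para to a large group, gives a 1.4-fold higher number from compound 2 to compound 3 (0.15 log units; within the scatter) in this assay and is the first measured change at this position. The broader change to 4-(methylsulfanyl)phenyl in place of 3-isopropoxy-4-methoxyphenyl gives a 1.3-fold higher number from compound 1 to compound 3 (0.12 log units; within the scatter) in the same assay, so neither change separates compound 3 from the other two compounds on these data. No available evidence explains the closeness of these numbers.

Still open, as far as these compounds go, is whether an amine, a carboxylic acid or a longer chain at this position would give a step beyond the scatter. The compounds shown also leave open whether replacing the silyl ether on the shared core would change the number.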